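Replacing a phenoxy ring with cyclohexyloxy in a serine phosphate ester

The compounds below may be only part of what the source reports. "The series", "measured", "known", "first", "only" and "open" are said of these compounds alone.

In an assay on cells for agonist activity at probable G-protein coupled receptor 34 (Mus musculus), with a stated time of 1 h (a higher number here means a larger maximal response, a lower number a smaller maximal response), compound 1 `N[C@@H](COP(=O)(O)OCCCOC(=O)CCc1ccccc1OCCCCOc1ccccc1)C(=O)O` gives 6.1%, while compound 2 `N[C@@H](COP(=O)(O)OCCCOC(=O)CCc1ccccc1OCc1cccc(Oc2ccccc2)c1)C(=O)O` reaches 19.4%, the higher of the two numbers and a gap beyond the usual scatter. Compound 3 `N[C@@H](COP(=O)(O)OCCCOC(=O)CCc1ccccc1OCc1cccc(OC2CCCCC2)c1)C(=O)O` carries one change relative to compound 2: cyclohexyl in place of phenyl on an oxygen on an aromatic ring. Among the measured compounds shown here, no measured pair shows this exchange, so its effect in this assay is unknown. The step of a number 2.4 percentage points lower from compound 2 to compound 3 (within the scatter) is expected to stay within the usual scatter, in no clear direction. For compound 3 the estimate in this assay is 17%, with a plausible range from 5% to 32%.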

Compound 3, largest response reached (Emax), in percent of the reference or control that the assay uses: 18.8%
Estimate against measurement, compound 3: 1.8 percentage points below, within the range that was stated.
By their numbers in this assay, from the lowest: compound 1; then compounds 3 and 2 (each within the scatter of the next).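

In this assay, cyclohexyl in place of phenyl on an oxygen on an aromatic ring is a number 0.6 percentage points lower from compound 2 to compound 3 (within the scatter) and thus shows that, at this position, the two six-carbon rings cannot be told apart by maximal response. An aromatic ring on this oxygen is therefore not needed to keep the response of compound 2. Nothing shown gives a reason for this result. Still open, as far as these compounds go, is how a piperidine ring, a cyclopentyl group or a longer carbon chain on this oxygen would read in this assay.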